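The source may hold more compounds than are shown below. What is called first, only, known or untested is meant among the compounds shown, and "the series" means these compounds.

The measured compounds and their values:

Compound 1, `Cc1cc(C)cc(OCCCON2C(N)=NC(N)=NC23CCOCC3)c1`, gives 88.6%.
Compound 2, `NC1=NC2(CCSCC2)N(OCCCOc2cccc(Cl)c2Cl)C(N)=N1`, gives 89.8%.
Compound 3, `Cc1ccc(OCCCON2C(N)=NC(N)=NC23CCOCC3)cc1`, has "not determined" (no result reported), so no number is available for it.

These results come from an assay on isolated protein for inhibition of Dihydrofolate reductase (Homo sapiens), read by spectrophotometry, using NADPH, with stated times of 5 s and 6 min, tested at 50 uM; a lower number here means a weaker effect, a higher number a stronger effect of the compound at the concentration tested. Compound 2 holds the higher of the two numbers that exist, but the gap to compound 1 lies within the usual scatter of repeated measurements, so the two compounds cannot be set in order against each other. Compound 3 adds nothing to the comparison, as no result was reported for it.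

The next compound, compound 4, has the structure `NC1=NC2(CCSCC2)N(OCCCOc2cccc(Br)c2)C(N)=N1`. It differs from compound 2 in one place:

3-bromophenyl in place of 2,3-dichlorophenyl on an oxygen on a saturated carbon

Within the data shown here, no pair of measured compounds differs in only one place, so there is no measured step to serve as a guide for this change. Both measured compounds sit close together near the top of the scale, which leaves little room for a rise and gives no reason to expect a marked fall. For compound 4 the step of a number 2.8 percentage points lower from compound 2 to compound 4 (within the scatter) is expected to stay within the scatter, with no clear direction. Compound 4 is therefore estimated at 87%, with a range from 74% to 95%.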

Compound 4, a percentage reported as inhibition, at one concentration (the size of the read-out at that concentration, not a potency): 86.5%
Compound 4: middle estimate off by 0.5 percentage points, on the high side; low and high end bracket the measured number.
By their numbers in this assay, from the lowest: compounds 4, 1 and 2 (each within the scatter of the next).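

In this assay, among these compounds, the first measured step at this position is a number 3.3 percentage points lower from compound 2 to compound 4 (within the scatter), so the two compounds cannot be told apart. On an oxygen on a saturated carbon, 3-bromophenyl and 2,3-dichlorophenyl therefore give the same read-out as far as this test can show, even though the swap changes both the kind and the number of halogen atoms on the ring. The read-out is taken at a single concentration and is not a potency, and no measurement here offers any explanation for this result.

Since two things change at once in this step, a 3-chlorophenyl group would be needed to separate the kind of halogen from the number of halogen atoms. The compounds shown also leave open how the read-out responds to an amine or a carboxylic acid on this phenyl ring, or to a longer chain carrying the ring.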